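The source may report more compounds than this note shows. Statements on the series, on what has been measured and on what is new or still open speak of the compounds shown alone.

Three thioureas sharing one core have been measured in a functional assay on A2780 cells (Homo sapiens) for inhibition, with a stated time of 72 h; on this read-out higher numbers stand for weaker inhibition and lower numbers for stronger inhibition. Compound 1 `CC1(C)CC(C)(C)c2cc(NC(=S)Nc3ccc(S(N)(=O)=O)cc3)ccc2O1` gives 6900 nM, compound 3 `CCC1(CC)CC(CC)(CC)c2cc(NC(=S)Nc3ccc([N+](=O)[O-])cc3)ccc2O1` gives 4600 nM, and compound 2 `CC1(C)CCOc2ccc(NC(=S)Nc3ccc(OC(F)(F)F)cc3)cc21` gives 4300 nM. Compound 2 has the lowest of the three numbers, but its gaps to compound 3 and to compound 1 both lie within the usual scatter of repeated measurements, so the three compounds cannot be told apart on this read-out.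

Compound 4 `CC1(C)CCOc2ccc(NC(=S)Nc3ccc(C(F)(F)F)cc3)cc21` has not yet been measured in this assay. It differs from compound 2 in one place: trifluoromethyl in place of trifluoromethoxy on an aromatic carbon. Going by the values given here, no pair of measured compounds differs by this change alone, so there is no step of this kind to build on. What can be said is that the three measured compounds, which differ from one another far more widely than compound 2 and compound 4 do, still all fall within the scatter of one another.

On that basis compound 4 is expected to give a number close to that of compound 2. The step of a 1.0-fold higher number from compound 2 to compound 4 (0.02 log units; within the scatter) is expected to lie within the scatter, in no particular direction. The estimated value for compound 4 in this assay is 4500 nM, with a range from 2000 nM to 10000 nM.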

Compound 4, half-maximal inhibitory concentration: 5500 nM
For compound 4 the middle estimate is 1.2-fold (0.09 log units) below the measured one; the measured number falls inside the stated range.
By their numbers in this assay, from the lowest: compounds 2, 3, 4 and 1 (each within the scatter of the next).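

In this assay, the change from trifluoromethoxy to trifluoromethyl on an aromatic carbon, para to a large group, gives a 1.3-fold higher number from compound 2 to compound 4 (0.11 log units; within the scatter). Going by these compounds alone, this is the first step that isolates a single place, and it shows that the two groups cannot be told apart at this position on this read-out. Removing the oxygen of trifluoromethoxy therefore produces no difference here that stands clear of the usual scatter, and nothing available accounts for this outcome.

The compounds shown leave open whether this position responds to any change at all, since only these two fluorinated groups can be compared directly on the same core, whereas compound 1 and compound 3 differ from them in more than one place. As far as these compounds go, whether an amine, a carboxylic acid or a plain hydrogen in this place would move the number beyond the scatter remains unknown, as does whether the same change would behave alike on a different core.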